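A few compounds are considered here, and "the series" means these few. Any claim that something is new, unique, unknown or untested is made for them only; others in the source may bear on it.

Compound 1 `NC(N)=NC(=O)c1nc(Cl)c(NC2CC2)nc1N` carries a cyclopropylamino group on the shared core, and in an assay for inhibition of acid-sensing ion channel 3 (Homo sapiens), read by patch clamp, tested at 1 uM (a lower number here means less inhibition, a higher number more inhibition at the concentration tested (going by the name of the read-out)), compound 1 has "not determined" (no result reported) as its reported result. Going by the values given here, compound 2 `CCCN(C)c1nc(N)c(C(=O)N=C(N)N)nc1Cl` is the only member with a number: in this assay compound 2 gives 32%. Compound 3 `CN1CCN(c2nc(N)c(C(=O)N=C(N)N)nc2Cl)CC1` has "not determined" (no result reported) in this assay, and compound 1 is the further entry without a single number, so compound 3 offers no measured anchor of its own. Compound 4 `COc1nc(N)c(C(=O)N=C(N)N)nc1Cl` differs from compound 3 in one place: methoxy in place of 4-methylpiperazin-1-yl on an aromatic carbon. With compound 3 unmeasured, the size and direction of the step to compound 4 in this assay cannot be judged from a number; only the value of compound 2 32% gives a rough scale. Compound 4 is expected to give about 25%, estimated between 5% and 50%.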

Compound 4, a percentage reported as inhibition, at one concentration (the size of the read-out at that concentration, not a potency): 21%
Estimate against measurement, compound 4: 4 percentage points above; the measured number falls inside the stated range.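

Going by these compounds alone, at this aromatic carbon, methoxy in place of methyl(propyl)amino gives, in this assay, a number 11 percentage points lower from compound 2 to compound 4 (beyond the scatter), the first measured step at this position. Inhibition persists with either group, so an oxygen-linked substituent as well as a nitrogen-linked one leaves a measurable read-out, while the step from compound 3 to compound 4 cannot be read. No measured finding here accounts for the lower number. Open, going by these compounds, is how an ethoxy group or a longer alkoxy chain would compare with methoxy here. Also open, on these data alone, is whether a primary amine at this carbon would fall nearer compound 2 or compound 4.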